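The source may report more compounds than this note shows. Statements on the series, on what has been measured and on what is new or still open speak of the compounds shown alone.

Three compounds built on one shared core were examined in an ADME assay on HEK293 cells (Homo sapiens) for cytotoxicity, read by MTT assay, with a stated time of 24 h; a lower number here means a stronger inhibitor, a higher number a weaker inhibitor. Compound 1 `FC(F)(F)c1ccc(C2CC(c3ccccc3)=NN2c2ccc(-c3ccccc3)nn2)cc1` reaches only a limit there, > 300000 nM. Compound 2 `COc1ccc(C2CC(c3ccccc3)=NN2c2ccc(-c3ccccc3)nn2)c(OC)c1` likewise gives only a limit, > 300000 nM. Compound 3 `Clc1ccc(C2=NN(c3ccc(-c4ccccc4)nn3)C(c3ccccc3)C2)cc1` also ends at a limit, > 300000 nM. Among the compounds with values here, the one step between neighbours, a step that the two limits leave unreadable from compound 1 to compound 2, cannot be read because of the limit of > 300000 nM in this assay, at which 3 of the 3 values shown sit. Compound 3 thus stands together with the other two at that limit, with no number of its own.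

Compound 4 `Fc1ccc(C2CC(c3ccc(Cl)cc3)=NN2c2ccc(-c3ccccc3)nn2)cc1` differs from compound 3 by fluoro in place of hydrogen on an aromatic carbon. Within the data shown here, no measured step touches this change, and the only step known is unreadable. Compound 4 is therefore expected to show no step beyond the scatter, a number no higher from compound 3 to compound 4 (the limit leaves the size open), and to stay at the limit. The estimate for compound 4 in this assay is 300000 nM, ranging from 150000 nM to 300000 nM.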

Compound 4, half-maximal inhibitory concentration: > 300000 nM
Compound 4 was reported as a limit; the forecaster's own chance of this, stated with the estimate: 85%; the middle value sits exactly at the limit.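

No step can be read from compound 3 to compound 4, because both end at the same limit: the limit of > 300000 nM in this assay, at which 4 of the 4 values shown sit.
The compounds shown leave open whether any change on the shared core would bring a readable number in this assay at all.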